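The source may report more compounds than this note shows. Statements on the series, on what has been measured and on what is new or still open speak of the compounds shown alone.

Compound 1 `OC[C@H]1O[C@@H](n2cnc3c(NCc4ccc(F)cc4)ncnc32)[C@H](O)[C@@H]1O`, compound 2 `OC[C@H]1O[C@@H](n2cnc3c(NCc4ccccc4Cl)ncnc32)[C@H](O)[C@@H]1O` and compound 3 `OC[C@H]1O[C@@H](n2cnc3c(NCc4cccc(O)c4O)ncnc32)[C@H](O)[C@@H]1O` share one core and differ only in the substituted phenyl group on the saturated chain carbon bound to nitrogen. In a functional assay on HOS cells (Homo sapiens) for antiproliferative activity, with a stated time of 72 h (on this read-out lower numbers stand for stronger inhibition and higher numbers for weaker inhibition), compound 1 gives 13200 nM. Compound 2 reads > 166000 nM, which is a limit of the assay and not a number. Compound 3 reads > 166000 nM, also only a limit. Compound 2 therefore stands at the limit of > 166000 nM in this assay, at which 2 of the 3 values shown sit.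

Compound 4 `OC[C@H]1O[C@@H](n2cnc3c(NCc4ccccc4OC(F)(F)F)ncnc32)[C@H](O)[C@@H]1O` departs from compound 2 in one place: trifluoromethoxy in place of chloro on an aromatic carbon. This puts trifluoromethoxy in place of chloro on an aromatic carbon, ortho to a large group. For the measured compounds named here, no measured step makes this exact exchange. The nearest evidence is an at least 12-fold higher number from compound 1 to compound 2 (1.09 log units; beyond the scatter) and an at least 12-fold higher number from compound 1 to compound 3 (1.09 log units; beyond the scatter), both large and both leading to the limit. Between the two limits there is only a step that the two limits leave unreadable from compound 2 to compound 3.

Compound 4 keeps the group on the same aromatic carbon as compound 2, so it is expected to remain close to that limit in this assay, with no clear gain in potency. The expected change is a step that the limit leaves unreadable from compound 2 to compound 4. For compound 4 the estimated value is 170000 nM, with an expected range from 50000 nM to 400000 nM, and a report of only a limit is the likelier outcome.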

Compound 4, half-maximal inhibitory concentration: > 166000 nM
Compound 4: no number, only a limit (the forecaster's own chance of this, stated with the estimate: 65%); the middle value lies beyond the limit too.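

In this assay compound 4 reads > 166000 nM, which is a limit of the assay and not a number. For the compounds shown here, compound 2 also has only a limit, so no step between compound 2 and compound 4 can be read. The compounds shown leave open whether trifluoromethoxy and chloro differ at all on this read-out.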